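A Phenyl Ester in Place of an Anilide

A few compounds are considered here, and "the series" means these few. Any claim that something is new, unique, unknown or untested is made for them only; others in the source may bear on it.

Compound 1 `CC1=C(C(=O)Nc2ccc(Br)cc2)C(c2ccccc2)NC(=O)N1` carries a (4-bromophenyl)amino group on the carbonyl carbon of the shared core. In an ADME assay on Vero cells (Chlorocebus sabaeus) for cytotoxicity, read by XTT assay, with a stated time of 72 h (on this read-out higher numbers stand for lower toxicity in this test and lower numbers for higher toxicity in this test), compound 1 reaches only a limit of the assay, > 100000 nM. Compound 2 `COc1cccc(C2NC(=O)NC(C)=C2C(=O)Nc2ccccc2Cl)c1` likewise reaches only a limit in this assay, > 100000 nM. Compound 3 `CC1=C(C(=O)Oc2ccccc2)C(c2ccccc2)NC(=S)N1` is reported in this assay as "non-toxic" (no number reported), without a number. Going by the values given here, compound 1 therefore stands at the ceiling of the values shown, because of the limit of > 100000 nM in this assay, at which 2 of the 3 values shown sit, and no measured step exists that would place it above or below another compound.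

The unmeasured compound 4 `CC1=C(C(=O)Oc2ccccc2)C(c2ccccc2)NC(=O)N1` differs from compound 1 in one place: phenoxy in place of (4-bromophenyl)amino on a carbonyl carbon. This leaves compound 4 as the oxo counterpart of compound 3, which is reported as non-toxic. Among the compounds with values here, since no step between measured compounds is available, the size of the change in this assay cannot be read from a measured pair; the expectation rests on all three entries lying at or beyond the limit. Compound 4 is expected to show a step of a number no higher from compound 1 to compound 4 (the limit leaves the size open), that is none beyond the scatter. The estimate for compound 4 in this assay is 100000 nM, within a range from 50000 nM to 300000 nM, and most likely again only a limit.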

Compound 4, half-maximal cytotoxic concentration: > 100000 nM
Compound 4 ended at the assay's limit; the forecaster's own chance of this, stated with the estimate: 85%; the middle value lies on the limit itself.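

In this assay, going by these compounds alone, compound 1 and compound 4 both rest at a limit of the assay, so no step between them can be read: the limit of > 100000 nM in this assay, at which 3 of the 4 values shown sit. The compounds shown leave open how far past that limit any of them lies, and whether any change on the shared core would bring a readable number.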